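The source may report more compounds than this note shows. Statements on the series, on what has been measured and on what is new or still open speak of the compounds shown alone.

The read-out throughout is an assay on liver for inhibition of sterol O-acyltransferase 1 (Rattus norvegicus), using microsomes; on this read-out lower numbers stand for stronger inhibition and higher numbers for weaker inhibition. The three compounds measured so far:

compound 1 `C=CCN(CC)S(=O)(=O)NC(=O)Nc1c(C(C)C)cccc1C(C)C` gives 2100 nM
compound 2 `CCCN(CCC)S(=O)(=O)NC(=O)Nc1c(C(C)C)cccc1C(C)C` gives 1100 nM
compound 3 `CC(C)c1cccc(C(C)C)c1NC(=O)NS(=O)(=O)N(C(C)C)C(C)(C)C` gives 140 nM

Compound 3 stands lowest of the three, and its steps to the other two lie beyond the scatter, so it is the most potent compound measured here. The step of a 15-fold lower number from compound 1 to compound 3 (1.18 log units; beyond the scatter) and the step of a 7.9-fold lower number from compound 2 to compound 3 (0.90 log units; beyond the scatter) both come from changing the group on the sulfonyl sulfur, while the step of a 1.9-fold lower number from compound 1 to compound 2 (0.28 log units; within the scatter) stays within the scatter. Compound 4 `CCCCCCOS(=O)(=O)NC(=O)Nc1c(C(C)C)cccc1C(C)C` carries the change (hexyloxy in place of isopropyl(tert-butyl)amino on a sulfonyl sulfur). For the measured compounds named here, no measured step involves an oxygen-linked chain at this place, so the only guide is that the isopropyl(tert-butyl)amino group gave the lowest number and the dipropylamino and allyl(ethyl)amino groups gave higher ones. The expectation for compound 4 in this assay is therefore a move back towards those higher numbers, a step of a 6.4-fold higher number from compound 3 to compound 4 (0.81 log units; beyond the scatter). Compound 4 is estimated at 900 nM, with a range from 250 nM to 3500 nM.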

Compound 4, half-maximal inhibitory concentration: 27000 nM
Estimate against measurement, compound 4: 30-fold (1.48 log units) below; the measured number lies above the stated range.
By their numbers in this assay, from the lowest: compound 3; then compounds 2 and 1 (each within the scatter of the next); then compound 4.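

Hexyloxy on the sulfonyl sulfur gives a far higher number in this assay than each of the three amino groups: isopropyl(tert-butyl)amino (a 190-fold higher number from compound 3 to compound 4 (2.29 log units; beyond the scatter)), dipropylamino (a 25-fold higher number from compound 2 to compound 4 (1.39 log units; beyond the scatter)) and allyl(ethyl)amino (a 13-fold higher number from compound 1 to compound 4 (1.11 log units; beyond the scatter)). The earlier compounds shown here carried only nitrogen-linked groups here, and compound 4 adds an oxygen-linked chain that stands as the weakest of the four, showing that this place can cost much more activity than those compounds revealed. Nothing measured here explains the loss.

The compounds shown leave open whether the loss follows the oxygen link or the hexyl chain itself, since both differ from the amino groups in compound 3. A hexylamino group on the same sulfur, or a shorter ethoxy group, would help separate the two.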